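Series notes: fluoro step from compound 1 to compound 4

The source may report more compounds than this note shows. Statements on the series, on what has been measured and on what is new or still open speak of the compounds shown alone.

Compound 1, `Cc1ccc(S(=O)(=O)N[C@@H](CC(=O)NC(C)(C)C)C(=O)NCCNC(=O)c2ccccc2)cc1`, in an ADME assay on HepG2 cells (Homo sapiens) for cytotoxicity; a lower number here means that less compound is needed, a higher number that more compound is needed for the effect: > 11000 nM, a limit.
Compound 2, `Cc1ccc(S(=O)(=O)N[C@@H](CC(=O)NC(C)(C)C)C(=O)NCCNC(=O)Nc2ccccc2)cc1`, in this assay: > 11000 nM, a limit.
Compound 3, `COc1cc(OC)cc(C(=O)NCCNC(=O)[C@H](CC(=O)NC(C)(C)C)NS(=O)(=O)c2ccc(C)cc2)c1`, in this assay: > 11000 nM, a limit.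

Compound 1 stands at the limit of this assay, as do the other two, so a step that the two limits leave unreadable from compound 1 to compound 2 and a step that the two limits leave unreadable from compound 1 to compound 3 are unreadable, as is a step that the two limits leave unreadable from compound 2 to compound 3. Compound 4, `Cc1ccc(S(=O)(=O)N[C@@H](CC(=O)NC(C)(C)C)C(=O)NCCNC(=O)c2cccc(F)c2)cc1`, differs from compound 1 by fluoro in place of hydrogen on an aromatic carbon. Within the data shown here, no measured step bears on this change in a readable way; every replacement on a carbonyl carbon so far left the value at the limit, because of the limit of > 11000 nM in this assay, at which 3 of the 3 values shown sit. No step beyond the scatter is therefore expected in this assay, and a step that the limit leaves unreadable from compound 1 to compound 4 is the expected outcome. Compound 4 is estimated at 15000 nM, within 8000 nM to 40000 nM.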

Compound 4, half-maximal effective concentration: > 11000 nM
Compound 4: a limit, no number; the forecaster's own chance of this, stated with the estimate: 85%; the middle value lies beyond the limit too.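

In this assay compound 4 gives > 11000 nM as a limit, so its steps from compound 1, compound 2 and compound 3 cannot be read. The compounds shown leave open whether any change to the shared core gives a readable value.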